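A few compounds are considered here, and "the series" means these few. Any claim that something is new, unique, unknown or untested is made for them only; others in the source may bear on it.

Of the compounds shown here, three built on one shared core have been tested in an assay on CHO cells for displacement of a labelled ligand from adenosine receptor A1 (Homo sapiens), read by scintillation counting, with a stated time of 120 min, tested at 10 uM; on this read-out lower numbers stand for less inhibition and higher numbers for more inhibition at the one concentration tested (going by the name of the read-out). Compound 1 `CC(C)N1CCN(Cc2csc(N)c2C(=O)c2ccc(Cl)cc2)CC1` gives 0%. Compound 2 `Nc1scc(CN2CCN(c3ccc(F)cc3Cl)CC2)c1C(=O)c1ccc(Cl)cc1` gives 0%. Compound 3 `Nc1scc(CN2CCN(c3cccc(F)c3)CC2)c1C(=O)c1ccc(Cl)cc1` gives 1%, the highest of the three numbers, yet the other two lie within the scatter of it: a number 1 percentage points higher from compound 1 to compound 3 (within the scatter) and a number 1 percentage points higher from compound 2 to compound 3 (within the scatter). Compound 4 `Nc1scc(CN2CCN(c3ccc(F)c(Cl)c3)CC2)c1C(=O)c1ccc(Cl)cc1` has not yet been measured; it differs from compound 3 in one place, where (3-chloro-4-fluorophenyl in place of 3-fluorophenyl on an amine nitrogen in a ring). Within the data shown here, the steps that bear on this change are the earlier exchanges of the group on the amine nitrogen in the ring: no change at the digits printed from compound 1 to compound 2 (within the scatter), a number 1 percentage points higher from compound 1 to compound 3 (within the scatter) and a number 1 percentage points higher from compound 2 to compound 3 (within the scatter), none of them beyond the scatter. Since every such exchange so far left the read-out unchanged, the expected step is no change at the digits printed from compound 3 to compound 4 (within the scatter), nothing beyond the scatter. Compound 4 is therefore estimated at 1%, with a range from -8% to 10%.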

Compound 4, a percentage reported as inhibition, at one concentration (the size of the read-out at that concentration, not a potency): 0%
The estimate for compound 4 lay 1 percentage points above the measured number; measured number inside the range.
By their numbers in this assay, from the lowest: compounds 1, 2, 4 and 3 (each within the scatter of the next).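

In this assay, 3-chloro-4-fluorophenyl in place of 3-fluorophenyl on the amine nitrogen in the ring gives a number 1 percentage points lower from compound 3 to compound 4 (within the scatter), and the same group gives no change at the digits printed from compound 2 to compound 4 (within the scatter) and no change at the digits printed from compound 1 to compound 4 (within the scatter). The position has now carried isopropyl and three different halogen-bearing phenyl groups, including one with 8 heavy atoms rather than 7, and no exchange among them goes beyond the scatter. No measurement shown here offers any explanation for this flat result.

The compounds shown leave open whether a different kind of group on this nitrogen, such as a carboxylic acid, a primary amine or a longer alkyl chain, would move the read-out beyond the scatter. They also leave open whether this position can influence the read-out at all.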